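This account rests on a few compounds, and the source may have more. Where it says the series, first, only, none or still open, it means among the compounds named here.

Compounds measured so far in a functional assay on BMDM cells (Mus musculus, strain C57BL/6) for inhibition, with a stated time of 2 days; a higher number here means a weaker inhibitor, a lower number a stronger inhibitor:

Compound 1, `Cc1cc(NC(=O)Cn2cc(-c3ccc([N+](=O)[O-])cc3)nn2)no1`, gives 1220 nM in this assay.
Compound 2, `COc1ccc(-c2cn(CC(=O)Nc3nc4ccccc4s3)nn2)cc1`, gives 1330 nM in this assay.
Compound 3, `O=C(Cn1cc(-c2ccc(F)cc2)nn1)Nc1nccs1`, gives 190 nM in this assay.

Among these three, compound 3 stands at the lowest number. Its gap to compound 1 and its gap to compound 2 both lie beyond the usual scatter of repeated measurements, so compound 3 is the strongest inhibitor of the set in this assay. Among the compounds with values here, the three compounds also differ from one another in more than one place, so no single step between measured compounds can be read from them.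

Compound 4, `O=C(Cn1cc(-c2ccccc2Cl)nn1)Nc1nccs1`, has not yet been measured. It differs from compound 3 in one place: 2-chlorophenyl in place of 4-fluorophenyl on an aromatic carbon. Within the data shown here, since no measured pair shows what such a change does in this assay, the expectation rests only on compound 3 itself. A modest weakening is expected from compound 3 to compound 4, of about a 2.1-fold higher number from compound 3 to compound 4 (0.32 log units; beyond the scatter), though a step within the scatter would not be surprising either. On that basis compound 4 is estimated at 400 nM in this assay, with a range from 120 nM to 1500 nM.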

Compound 4, half-maximal inhibitory concentration: 60 nM
Estimate against measurement, compound 4: 6.7-fold (0.82 log units) above; measured number below the stated range.
By their numbers in this assay, from the lowest: compound 4; then compound 3; then compounds 1 and 2 (each within the scatter of the next).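

Within the data shown here, the swap of 4-fluorophenyl for 2-chlorophenyl on an aromatic carbon of the five-membered aromatic ring with 3 nitrogen gives the first reading of a single change in this assay: a 3.2-fold lower number from compound 3 to compound 4 (0.50 log units; beyond the scatter). The step lies beyond the usual scatter, so this position responds to what the attached phenyl ring carries, and with the rest of the molecule held constant, a ring of the same size and the same counted hydrogen-bond features gives a stronger inhibitor, with compound 4 at 60 nM in this assay. Nothing shown here gives a reason for this gain.

The change replaces fluorine with chlorine and moves the halogen on the phenyl ring in one step, so the compounds shown cannot separate the two, and 4-chlorophenyl, 2-fluorophenyl or plain phenyl at this position would be needed to do so. Also open, going by these compounds, is whether 2-chlorophenyl would bring a similar gain on the core of compound 1 or the core of compound 2, since each of these differs from compound 4 in more than one place.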